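Aryl variation at a shared core: expectation for compound 4

The source may hold more compounds than are shown below. What is called first, only, known or untested is meant among the compounds shown, and "the series" means these compounds.

Measured in a functional assay, with a stated time of 90 s; on this read-out higher numbers stand for weaker inhibition and lower numbers for stronger inhibition:
compound 1, `Cc1nc2c3ccccc3ccc2c2nc3c(ccc4ccccc43)c(-c3ccccc3Cl)c12`: 170 ug/mL
compound 2, `Cc1nc2c3ccccc3ccc2c2nc3c(ccc4ccccc43)c(-c3ccccc3S)c12`: 158 ug/mL
compound 3, `Cc1nc2c3ccccc3ccc2c2nc3c(ccc4ccccc43)c(-c3cc([N+](=O)[O-])ccc3N)c12`: 110 ug/mL

Compound 3 holds the lowest of the three numbers, but its separation from compound 2 and from compound 1 is within the scatter, so no order among the three can be read. The changes at the pendant aryl gave a 1.1-fold lower number from compound 1 to compound 2 (0.03 log units; within the scatter), a 1.5-fold lower number from compound 1 to compound 3 (0.19 log units; within the scatter) and a 1.4-fold lower number from compound 2 to compound 3 (0.16 log units; within the scatter); three different groups at the same aromatic carbon left this assay essentially unmoved.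

Compound 4, `Cc1nc2c3ccccc3ccc2c2nc3c(ccc4ccccc43)c(-c3nccnc3N)c12`, carries 3-aminopyrazin-2-yl in place of 2-amino-5-nitrophenyl on an aromatic carbon. Among the compounds with values here, the steps that bear on this change are those just named, all within the scatter, and they are the only guidance available: nothing shows a pendant group at this carbon moving the number beyond the scatter. No step beyond the scatter is therefore expected in either direction. The expected step is a 1.1-fold higher number from compound 3 to compound 4 (0.04 log units; within the scatter). Compound 4 is estimated at 120 ug/mL, with a range from 60 ug/mL to 250 ug/mL.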

Compound 4, half-maximal inhibitory concentration: 134 ug/mL
Beside the measured number, compound 4's estimate is 1.1-fold (0.05 log units) below it; the range from low to high includes it.
By their numbers in this assay, from the lowest: compounds 3, 4, 2 and 1 (each within the scatter of the next).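

In this assay the 3-aminopyrazin-2-yl group gives a 1.2-fold higher number from compound 3 to compound 4 (0.09 log units; within the scatter) and a 1.2-fold lower number from compound 2 to compound 4 (0.07 log units; within the scatter) and a 1.3-fold lower number from compound 1 to compound 4 (0.10 log units; within the scatter) at this aromatic carbon, so a pendant ring with 2 hetero atoms stands here with no step beyond the scatter. Among the compounds shown, the pendant ring at this position therefore need not be of carbon only, and the nitro group of compound 3 is not needed to keep the number in this range. No measurement at hand bears on why the number stays so flat across these groups.

Open, as far as these compounds go, is whether any group at this carbon can move the number beyond the scatter, for example a carboxylic acid, a piperidine or a longer alkyl chain in place of the aromatic ring. Also open is whether replacing the methyl group on the shared core, which every compound shown carries, would move the number.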